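Swapping the Amide Tail in a Cell-Growth Series

The source may hold more compounds than are shown below. What is called first, only, known or untested is meant among the compounds shown, and "the series" means these compounds.

Measured so far:
compound 1 `C/C=C/C(=O)Nc1cc2c(N3CCc4ccccc43)ncnc2cc1O[C@@H]1CCOC1` — 5220 nM
compound 2 `COc1cc2ncnc(N3CCCc4ccccc43)c2cc1NC(=O)C=C(C)C` — 6130 nM
compound 3 `CC(C)=CC(=O)Nc1cc2c(N3CCCc4ccccc43)ncnc2cc1O[C@@H]1CCOC1` — 9020 nM

In a functional assay on PC-3 cells (Homo sapiens) for antiproliferative activity, read by MTT assay, with a stated time of 72 h (on this read-out higher numbers stand for weaker inhibition and lower numbers for stronger inhibition), compound 2 gives 6130 nM. Among the three numbers it stands second highest, with compound 1 nearest and compound 3 furthest, and both of those gaps lie within the scatter, so no order among the three can be read. Compound 4 `COc1cc2ncnc(N3CCCc4ccccc43)c2cc1NC(=O)/C=C/CN1CCN(C)CC1` is not yet measured. It differs from compound 2 in one place: 3-(4-methylpiperazin-1-yl)prop-1-en-1-yl in place of 2-methylprop-1-en-1-yl on a carbonyl carbon. Among the measured compounds shown here, the only measured step, a 1.5-fold higher number from compound 2 to compound 3 (0.17 log units; within the scatter), concerns the group on the oxygen of the aromatic ring and leaves the amide side untouched, so it does not speak to this change; it does show that a single substitution can pass without a shift beyond the scatter. For the measured compounds named here, with no step bearing on the carbonyl side, the expectation for compound 4 rests on compound 2 alone and is loose. Compound 4 is expected to give 4000 nM, between 1200 nM and 13000 nM, which would mean an estimated step of a 1.5-fold lower number from compound 2 to compound 4 (0.19 log units; within the scatter).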

Compound 4, half-maximal inhibitory concentration: 6260 nM
Compound 4: middle estimate off by 1.6-fold (0.19 log units), on the low side, and the stated range covers the measured number.
By their numbers in this assay, from the lowest: compounds 1, 2, 4 and 3 (each within the scatter of the next).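

Among the compounds shown here, this is the first look at the amide side of the series. With compound 2 as the reference, 3-(4-methylpiperazin-1-yl)prop-1-en-1-yl replaces 2-methylprop-1-en-1-yl on the carbonyl carbon, bringing in a six-membered non-aromatic ring with 2 hetero atoms, and this assay shows a 1.0-fold higher number from compound 2 to compound 4 (0.01 log units; within the scatter) as the step. So, for this one swap in this one cell assay, a much bigger group with hydrogen-bond acceptors leaves the number unchanged within the scatter, and nothing available explains why.

Going by these compounds, whether the same holds for other groups at this place remains open, for example a morpholine ring, a dimethylamine or a longer carbon chain carrying the same piperazine ring. On these data alone, it is also open whether this tail would behave the same way with oxolan-3-yl on the oxygen instead of methyl.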